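Replacing the Acid of Compound 1 with a Piperazine Amide

This account rests on a few compounds, and the source may have more. Where it says the series, first, only, none or still open, it means among the compounds named here.

Measured compounds:
compound 1 `COc1cc2c(cc1OC)C(CC(=O)O)CC2`: 20.4%
compound 2 `CCCCCNC(=O)CC1CCc2cc(OC)c(OC)cc21`: 35.2%

In a functional assay on the whole organism (strain Wistar) for inhibition, with Rattus norvegicus as the target, read by paw edema, with stated times of 60 min and 6 h, at a dose of 100 mg/kg by the oral route (on this read-out lower numbers stand for less inhibition and higher numbers for more inhibition at the one dose given (going by the name of the read-out)), compound 1 stands lowest of the two measured numbers. Among the compounds with values here, the one measured step, a number 14.8 percentage points higher from compound 1 to compound 2 (beyond the scatter), is the only guide to the change at hand, since it too replaces the hydroxy of the acid with an amine on the carbonyl carbon. Compound 3 `COc1cc2c(cc1OC)C(CC(=O)N1CCNCC1)CC2` differs from compound 1 in this way: piperazin-1-yl in place of hydroxy on a carbonyl carbon. Compound 3 is therefore expected to show a modest rise of similar size, a number 10.6 percentage points higher from compound 1 to compound 3 (beyond the scatter). The estimate for compound 3 is 31%, with a range from 14% to 48%.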

Compound 3, a percentage reported as inhibition, in the whole organism at one dose (the size of the read-out at that dose, not a potency): 33.3%
Compound 3: the middle estimate sits 2.3 percentage points below what was measured, within the range that was stated.
By their numbers in this assay, from the lowest: compound 1; then compounds 3 and 2 (each within the scatter of the next).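

In this assay, a second, different amine on the carbonyl carbon also lifts the number over the acid, a number 12.9 percentage points higher from compound 1 to compound 3 (beyond the scatter), so the rise does not depend on pentylamino alone. The ring of piperazin-1-yl and the open chain of pentylamino give numbers that cannot be told apart, a number 1.9 percentage points lower from compound 2 to compound 3 (within the scatter). Nothing available here explains the rise from the acid.

From the compounds shown here alone, whether morpholin-4-yl or 4-methylpiperazin-1-yl on the same carbonyl carbon would give a similar number remains open. So does the outcome with a shorter chain such as ethylamino.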